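Cyclopentyl to 3-Chlorophenyl on the Amine of a Shared Core

The source may report more compounds than this note shows. Statements on the series, on what has been measured and on what is new or still open speak of the compounds shown alone.

Compound 1 `O=C1C=C(NC2CCCC2)C(=O)c2c1nc1n2[C@H]2OC[C@@H](O)[C@H]2OC1` — in a functional assay on ECa-109 cells for inhibition, with ECa-109 cell line (Homo sapiens) as the target, read by sulforhodamine B assay (a lower number here means a stronger inhibitor, a higher number a weaker inhibitor), compound 1 gives > 16000 nM, which is a limit of the assay and not a number.
Compound 2 `O=C1C(NCc2ccccc2)=CC(=O)c2c1nc1n2[C@H]2OC[C@@H](O)[C@H]2OC1` — in this assay compound 2 gives > 8000 nM, again a limit rather than a number.

Compound 1 therefore stands at the limit of > 16000 nM in this assay, at which 1 of the 2 values shown sits, so no more than a limit is known for it. Compound 2 sits at the limit of > 8000 nM in this assay, at which 1 of the 2 values shown sits. Within the data shown here, the two values show only that both compounds lie beyond their limits; no measured step between them is available, and nothing orders one above the other.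

Compound 3 `O=C1C=C(Nc2cccc(Cl)c2)C(=O)c2c1nc1n2[C@H]2OC[C@@H](O)[C@H]2OC1` has not yet been measured in this assay. It differs from compound 1 by 3-chlorophenyl in place of cyclopentyl on an amine nitrogen. No measured step of this kind exists among the compounds shown, so the size of the change can only be guessed. Compound 1 itself shows only the limit > 16000 nM in this assay. The step expected from this change is an at least 1.6-fold lower number from compound 1 to compound 3 (0.20 log units; that floor lies within the scatter), a modest move toward stronger inhibition that could well stay within the scatter or end again at a limit. Compound 3 is accordingly estimated at 10000 nM in this assay, with a range from 2500 nM to 40000 nM.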

Compound 3, half-maximal inhibitory concentration: 4690 nM
Beside the measured number, compound 3's estimate is 2.1-fold (0.33 log units) above it; the range from low to high includes it.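

In this assay, compound 3 gives the only real number among the compounds shown, and placing 3-chlorophenyl instead of cyclopentyl on the amine nitrogen produces an at least 3.4-fold lower number from compound 1 to compound 3 (0.53 log units; beyond the scatter). This shows that the read-out on these cells responds to the group at this amine nitrogen, something the two limits alone could not establish. The step is a floor rather than a measured size, for compound 1 is known only through a limit: the limit of > 16000 nM in this assay, at which 1 of the 3 values shown sits.

The compounds shown do not separate the contribution of the aromatic ring from that of the chlorine, a question that a plain phenyl group on the same nitrogen, compared with the 3-chlorophenyl of compound 3, would address. Also open, going by these compounds, is how far the read-out would move with other groups at this nitrogen, such as 3-methoxyphenyl, cyclohexyl or a longer carbon chain, and whether any of them would give a lower number than compound 3 or end again at a limit.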